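Swapping methoxy for methyl in compound 3

The source may report more compounds than this note shows. Statements on the series, on what has been measured and on what is new or still open speak of the compounds shown alone.

Values measured in an ADME assay on HUVEC cells (Homo sapiens) for cytotoxicity, read by MTT assay, with a stated time of 24 h (on this read-out higher numbers stand for lower toxicity in this test and lower numbers for higher toxicity in this test), for three compounds
- Compound 1 `Cc1ccc(/C=C/c2nnc(-c3ccc4c(c3)OCCO4)o2)cc1` gives 265000 nM
- Compound 2 `Fc1ccccc1/C=C/c1nnc(-c2ccc3c(c2)OCCO3)o1` gives 402000 nM
- Compound 3 `COc1cccc(/C=C/c2nnc(-c3ccc4c(c3)OCCO4)o2)c1` gives 332000 nM

These three compounds share one core and differ only in the aromatic group on the double-bonded chain. Compound 3 cannot be told apart from the other two, since the data show a 1.2-fold lower number from compound 2 to compound 3 (0.08 log units; within the scatter) and a 1.3-fold higher number from compound 1 to compound 3 (0.10 log units; within the scatter).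

The next structure, compound 4 `Cc1cccc(/C=C/c2nnc(-c3ccc4c(c3)OCCO4)o2)c1`, differs from compound 3 in a single group. It has methyl in place of methoxy on an aromatic carbon, so 3-methoxyphenyl becomes 3-methylphenyl (methyl in place of methoxy on an aromatic carbon).

Among the compounds with values here, no measured pair makes exactly this swap. The closest evidence is compound 1, which also carries a methyl on its aromatic ring, though not as 3-methylphenyl, and its step to compound 3 stayed small. The change of aromatic group in a 1.5-fold higher number from compound 1 to compound 2 (0.18 log units; within the scatter) was also small. Three compounds are a thin basis, but they give no reason to expect a step beyond the scatter in this assay, and no direction can be favoured.

The expected result is a 1.1-fold lower number from compound 3 to compound 4 (0.03 log units; within the scatter). For compound 4 the estimated value is 310000 nM, with an expected range from 190000 nM to 500000 nM.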

Compound 4, half-maximal cytotoxic concentration: 201000 nM
Compound 4: the middle estimate sits 1.5-fold (0.19 log units) above what was measured; low and high end bracket the measured number.
By their numbers in this assay, from the lowest: compounds 4, 1, 3 and 2 (each within the scatter of the next).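

In this assay the exact swap of methoxy for methyl on this aromatic carbon can now be read directly as a 1.7-fold lower number from compound 3 to compound 4 (0.22 log units; within the scatter) and so does not separate the two groups. Moving from 4-methylphenyl to 3-methylphenyl gives a 1.3-fold lower number from compound 1 to compound 4 (0.12 log units; within the scatter) and replacing 2-fluorophenyl with 3-methylphenyl gives a 2.0-fold lower number from compound 2 to compound 4 (0.30 log units; within the scatter) as the largest step in this set, yet it too is printed as within the scatter. The four compounds therefore cannot be ranked against one another in this test, and no evidence is available to explain where their numbers fall.

As far as these compounds go, the groups on this ring so far are limited to methyl, methoxy and fluoro, so it remains open whether an amine, a carboxylic acid or a longer chain in this place would produce a step beyond the scatter. From the compounds shown here alone, it is equally open whether a change to the shared core, which is identical in all four compounds, would do so.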